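The source may report more compounds than this note shows. Statements on the series, on what has been measured and on what is new or still open speak of the compounds shown alone.

Compound 1 `CCOc1cc(NC(=O)C2(NC(=O)c3ccc4c(C5CCCC5)c(-c5ncc(Cl)cn5)n(C)c4c3)CCC2)ccc1/C=C/C(=O)OCC(C)C` and compound 2 `CCOc1cc(NC(=O)C2(NC(=O)c3ccc4c(C5CCCC5)c(-c5ncc(Cl)cn5)n(C)c4c3)CCC2)ccc1/C=C/C(=O)OCc1ccccc1` share one core and differ only in the group on the saturated chain carbon bound to an oxygen next to a carbonyl group. In an ADME assay on a cell-free system (plasma, Homo sapiens) for pharmacokinetics (on this read-out lower numbers stand for a shorter-lived compound and higher numbers for a longer-lived compound), compound 1 gives 6.18 h. For compound 2 this assay reports only a limit, > 5 h, so compound 2 stands on a range rather than a number. The step that the limit leaves unreadable from compound 1 to compound 2 therefore cannot be read in size, a consequence of the limit of > 5 h in this assay, at which 1 of the 2 values shown sits. Compound 3 `CCOc1cc(NC(=O)C2(NC(=O)c3ccc4c(C5CCCC5)c(-c5ncc(Cl)cn5)n(C)c4c3)CCC2)ccc1/C=C/C(=O)OCC(=O)N1CCOCC1` has not yet been measured in this assay, and it carries (morpholin-4-yl)carbonyl in place of phenyl on a saturated chain carbon bound to an oxygen next to a carbonyl group. Within the data shown here, no measured step bears readably on this change, so the only anchor is the range of compound 2. The step of an at least 1.2-fold lower number from compound 2 to compound 3 (0.09 log units; that floor lies within the scatter) is expected to stay small, with no clear direction. Compound 3 is estimated to give about 4 h in this assay, expected to fall between 1.5 h and 8 h.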

Compound 3, half-life: > 5 h
Compound 3: a limit, no number; the forecaster's own chance of this, stated with the estimate: 30%; middle value at least 1.2-fold (0.09 log units) from the limit.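

Among these compounds, compound 3, like compound 2, returns only a limit in this assay, so no step among compound 1, compound 2 and compound 3 can be read in size, because of this: the limit of > 5 h in this assay, at which 2 of the 3 values shown sit. From the compounds shown here alone, the actual half-lives of compound 2 and compound 3, and whether (morpholin-4-yl)carbonyl in place of phenyl changes the half-life at all, remain open.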